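Replacing naphthalen-2-yl in compound 2

The source may report more compounds than this note shows. Statements on the series, on what has been measured and on what is new or still open speak of the compounds shown alone.

In a functional assay on A2780 cells (Homo sapiens) for antiproliferative activity, read by fluorescence, with a stated time of 72 h (on this read-out lower numbers stand for stronger inhibition and higher numbers for weaker inhibition), compound 2 (`CN1CCC(C(=O)N2Cc3c(NC(=O)c4ccc5ccccc5c4)n[nH]c3C2(C)C)CC1`) gives 270 nM and lies within the scatter of compound 1 (`CC1(C)c2[nH]nc(NC(=O)c3ccc(F)cc3)c2CN1C(=O)C1CCN(C2CC2)CC1`) with 380 nM as its number. Compound 3 (`CN(C)CC(=O)Nc1n[nH]c2c1CN(C(=O)C(C)(C)C)C2(C)C`) gives 580 nM and stands higher than compound 2 by more than the scatter. Compound 4 (`CN1CCC(C(=O)N2Cc3c(NC(=O)Nc4cccc(F)c4)n[nH]c3C2(C)C)CC1`) is still unmeasured and differs from compound 2 as follows ((3-fluorophenyl)amino in place of naphthalen-2-yl on a carbonyl carbon): (3-fluorophenyl)amino in place of naphthalen-2-yl on a carbonyl carbon. For the measured compounds named here, no pair of measured compounds differs in one place only, so no measured step guides this change. No step beyond the scatter is expected, in either direction: the estimated 1.1-fold higher number from compound 2 to compound 4 (0.05 log units; within the scatter) in this assay is small. In this assay compound 4 is expected at 300 nM within an estimated range of 90 nM to 1000 nM as a number, not a limit.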

Compound 4, half-maximal inhibitory concentration: 350 nM
Beside the measured number, compound 4's estimate is 1.2-fold (0.07 log units) below it; the measured number falls inside the stated range.
By their numbers in this assay, from the lowest: compounds 2, 4, 1 and 3 (each within the scatter of the next, the first and the last beyond it).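

For the compounds shown here, at the carbonyl carbon whose other neighbour is the amide-type nitrogen, the only one-place step gives a 1.3-fold higher number from compound 2 to compound 4 (0.11 log units; within the scatter) in this assay. This read-out therefore does not separate naphthalen-2-yl, with two aromatic rings, from (3-fluorophenyl)amino, with one ring and a hydrogen-bond donor. No measured evidence bears on the reason for this result.

On these data alone, whether the ring count, the added nitrogen or the fluorine matters here remains open. Plain phenyl and phenylamino groups on the same carbonyl carbon would separate these features.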